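The source may hold more compounds than are shown below. What is called first, only, known or untested is meant among the compounds shown, and "the series" means these compounds.

Measured compounds:
Compound 1, `COc1cc(CNc2nc3cc(N)cc(N)c3nc2-c2ccccc2)cc(OC)c1OC` — in a functional assay on NCI/ADR-RES cells (Homo sapiens) for inhibition, read by sulforhodamine B assay, with a stated time of 48 h (a higher number here means a weaker inhibitor of growth, a lower number a stronger inhibitor of growth), compound 1 gives 10200 nM.
Compound 2, `Nc1cc(N)c2nc(-c3ccccc3)c(NCc3ccc(F)cc3)nc2c1` — in this assay compound 2 gives 2450 nM.
Compound 3, `COc1ccc(Sc2nc3cc(N)cc(N)c3nc2-c2ccccc2)cc1` — in this assay compound 3 gives only a limit of the assay, < 100000 nM.

For the measured compounds named here, compound 3 therefore stands on no number at all in this assay; its reading is a limit, and it is the one value of the three that sits at the limit of < 100000 nM in this assay, at which 1 of the 3 values shown sits. Going by the values given here, the measured step that the limit leaves unreadable from compound 2 to compound 3 is for that reason of unknown size, so the only readable numbers come from compound 1 and compound 2.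

Compound 4, `Nc1cc(N)c2nc(-c3ccccc3)c(Oc3ccc(F)cc3)nc2c1`, is the next compound and is not yet measured. It differs from compound 3 by 4-fluorophenoxy in place of (4-methoxyphenyl)sulfanyl on an aromatic carbon. Among the compounds with values here, no measured step bears on this change: the one step that touches compound 3 cannot be read, and compound 1 and compound 2 show only that two benzylamino groups at this place give measurable growth inhibition. The expected step that the limit leaves unreadable from compound 3 to compound 4 is therefore set loosely. Compound 4 is estimated at 20000 nM in this assay, within a range from 3000 nM to 100000 nM.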

Compound 4, concentration for 50% growth inhibition: 18200 nM
Beside the measured number, compound 4's estimate is 1.1-fold (0.04 log units) above it; measured number inside the range.
By their numbers in this assay, from the lowest: compound 2; then compounds 1 and 4 (each within the scatter of the next).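

Compound 4 is the first compound shown with an oxygen-linked aryl group at this place, next to the ring nitrogen, and it gives a readable number. In this assay, 4-fluorophenoxy in place of (4-fluorobenzyl)amino gives a 7.4-fold higher number from compound 2 to compound 4 (0.87 log units; beyond the scatter), so at this place the amino-linked group is not required for measurable growth inhibition, although this single pair favours it. The steps that touch compound 3 cannot be read because its reading is a limit, so the sulfur-linked group cannot be compared with either of the others: the limit of < 100000 nM in this assay, at which 1 of the 4 values shown sits.

For the compounds shown here, the one readable step changes both the linking atom and the benzyl group, so it cannot show which of the two accounts for the difference. On these data alone, how a 4-fluoroanilino group, which keeps the nitrogen link without the benzyl carbon, or a morpholine would read here remains open.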